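Three Limit Readings and a Fourth Compound to Come

This account rests on a few compounds, and the source may have more. Where it says the series, first, only, none or still open, it means among the compounds named here.

Three compounds have been read in an ADME assay on HCT-116 cells (Homo sapiens) for cytotoxicity, read by CellTiter-Glo, with a stated time of 72 h (on this read-out lower numbers stand for stronger inhibition and higher numbers for weaker inhibition), and each gave only a limit:

compound 1 `CC1CCN(C2CCN(S(=O)(=O)c3cn(C)cn3)CC2)CC1` — a limit, > 10000 nM
compound 2 `COc1ccc(Br)cc1S(=O)(=O)N1CCC(N2CCC(C)CC2)CC1` — a limit, > 5000 nM
compound 3 `Cc1cc(C)c(S(=O)(=O)N2CCN(C3CCN(C)CC3)CC2)c(C)c1` — a limit, > 5000 nM

Compound 1 stands at the limit of > 10000 nM in this assay, at which 1 of the 3 values shown sits. Compounds 2 and 3 sit at the limit of > 5000 nM in this assay, at which 2 of the 3 values shown sit. Among the measured compounds shown here, none of the three returned a number, so no step between measured compounds can be drawn, and nothing in this set separates one compound from another beyond the usual scatter of this assay.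

Compound 4 `CC1CCN(C2CCN(S(=O)(=O)c3cccnc3F)CC2)CC1` keeps the core of compound 1 and changes one group on the sulfonyl sulfur: 2-fluoropyridin-3-yl in place of 1-methyl-1H-imidazol-4-yl on a sulfonyl sulfur. For the measured compounds named here, there is no measured step to lean on. Since compound 1 reaches only the limit > 10000 nM, the expectation for compound 4 is that it returns a limit as well, with no step beyond the scatter in either direction. The step from compound 1 to compound 4 is expected to be a number no higher from compound 1 to compound 4 (the limit leaves the size open). Compound 4 is therefore estimated at 10000 nM, with a range from 3000 nM to 30000 nM, and most likely reported only as a limit.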

Compound 4, half-maximal inhibitory concentration: > 10000 nM
Compound 4: a limit, no number; the forecaster's own chance of this, stated with the estimate: 80%; the middle value lies on the limit itself.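

In this assay compound 4 returns only a limit, > 10000 nM. Compound 1 also gives only a limit, > 10000 nM. Between these two limits, no step from compound 1 to compound 4 can be read. The compounds shown leave open whether 2-fluoropyridin-3-yl in place of 1-methyl-1H-imidazol-4-yl on a sulfonyl sulfur changes the read-out at all.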